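Cytotoxicity notes: carboxy to methylsulfonylethyl on the shared core

The source may report more compounds than this note shows. Statements on the series, on what has been measured and on what is new or still open speak of the compounds shown alone.

In an ADME assay on HEp-2 cells (Homo sapiens) for cytotoxicity, read by CCK-8 assay, with a stated time of 6 days (a higher number here means that more compound is tolerated, a lower number that less compound is tolerated), compound 3 `O=C(O)c1c(Cn2c(=O)n(C3CC3)c3ccncc32)nc2cc(Cl)ccn12` gives only a limit, > 100000 nM. Compound 1 `O=c1n(Cc2nc3ccc(C(F)(F)F)cn3c2CCCCO)c2cnccc2n1C1CC1` likewise gives a limit, > 100000 nM. Compound 2 `O=c1n(Cc2nc3ccccn3c2CCCCO)c2cnccc2n1C1CC1` also gives a limit, > 100000 nM. Within the data shown here, the one step between measured compounds, a step that the two limits leave unreadable from compound 1 to compound 2, cannot be read, since both of its values sit at the limit (the limit of > 100000 nM in this assay, at which 3 of the 3 values shown sit). Among the measured compounds shown here, no measured step in this assay therefore has a size.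

Compound 4 `CS(=O)(=O)CCc1c(Cn2c(=O)n(C3CC3)c3ccncc32)nc2cc(Cl)ccn12` differs from compound 3 by 2-(methylsulfonyl)ethyl in place of carboxy on an aromatic carbon. Nothing measured bears on this change with a readable size; the three values all lie at the limit (the limit of > 100000 nM in this assay, at which 3 of the 3 values shown sit), and where compound 3 stands is known only as that limit. The expectation for compound 4 in this assay is that it too sits at the limit. The step of a number no higher from compound 3 to compound 4 (the limit leaves the size open) is expected to be none beyond the scatter. Compound 4 is estimated at 100000 nM, from 30000 nM to 300000 nM, with a limit rather than a number the likely report.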

Compound 4, half-maximal cytotoxic concentration: > 100000 nM
Compound 4 gave a limit, no number; the forecaster's own chance of this, stated with the estimate: 85%; the middle value lies on the limit itself.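

The step from compound 3 to compound 4 cannot be read in this assay, since both values are limits: the limit of > 100000 nM in this assay, at which 4 of the 4 values shown sit.

The compounds shown leave open whether 2-(methylsulfonyl)ethyl in place of carboxy shifts tolerance at all, and at what concentration any compound in this series becomes cytotoxic.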